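Adding a hydroxy to compound 2

The compounds below may be only part of what the source reports. "The series", "measured", "known", "first", "only" and "open" are said of these compounds alone.

In a functional assay on P388 cells (Mus musculus) for antiproliferative activity, read by colorimetric assay and MTT assay (on this read-out higher numbers stand for weaker inhibition and lower numbers for stronger inhibition), compound 1 (`COc1ccc(S(=O)(=O)Nc2cccc3cc(O)[nH]c23)cc1`) gives 0.11 ug/mL and compound 2 (`O=S(=O)(Nc1cccc2cc[nH]c12)c1ccc(Cl)cc1`) gives 6 ug/mL on the same read-out. Compound 2 thus holds the higher of the two numbers, and its gap to compound 1 lies beyond the scatter. The two differ in more than one place, so the gap cannot be assigned to any single group. Compound 3 (`O=S(=O)(Nc1cccc2cc(O)[nH]c12)c1ccc(Cl)cc1`) departs from compound 2 by one change, hydroxy in place of hydrogen on an aromatic carbon in all, which is hydroxy in place of hydrogen on an aromatic carbon, next to the ring nitrogen. Compound 1 (0.11 ug/mL) already carries hydroxy at that place, and this is the only hint available. The expected move is a 15-fold lower number from compound 2 to compound 3 (1.18 log units; beyond the scatter) in this assay and would lie beyond the scatter, towards stronger inhibition. For compound 3 the estimated value is 0.4 ug/mL (expected range 0.08 ug/mL to 2.5 ug/mL).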

Compound 3, half-maximal inhibitory concentration: 2.2 ug/mL
Compound 3: middle estimate off by 5.5-fold (0.74 log units), on the low side, and the stated range covers the measured number.
By their numbers in this assay, from the lowest: compound 1; then compound 3; then compound 2.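

In this assay, hydroxy in place of hydrogen on an aromatic carbon, next to the ring nitrogen, gives a 2.7-fold lower number from compound 2 to compound 3 (0.44 log units; beyond the scatter) on its own, so this change moves the number towards stronger inhibition, but only modestly. With hydroxy present in both compounds, chloro in place of methoxy on an aromatic carbon gives a 20-fold higher number from compound 1 to compound 3 (1.30 log units; beyond the scatter) in the same assay, a larger step than the one for adding hydroxy. No evidence is available here to explain either step.

As far as these compounds go, whether an amine or a carboxylic acid at this place would match hydroxy remains open. The compounds shown also leave open whether adding hydroxy would produce a step of the same size when methoxy stands in place of chloro, since only the compound with hydroxy carries methoxy.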